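A few compounds are considered here, and "the series" means these few. Any claim that something is new, unique, unknown or untested is made for them only; others in the source may bear on it.

Measured in a functional assay on HL-60 cells (Homo sapiens) for cytotoxicity; a lower number here means a stronger inhibitor, a higher number a weaker inhibitor:
Compound 1 `COC(=O)C1C(c2oc(=O)c(CO)c(OC)c2CO)C(C(=O)OC)C1c1oc(=O)c(CO)c(OC)c1CO`: > 50000 nM (a limit)
Compound 2 `COC(=O)/C=C/c1oc(=O)c(COC(C)=O)c(OC)c1CO`: 650 nM
Compound 3 `COc1c(C)c(/C=C/C(=O)O)oc(=O)c1CO`: > 50000 nM (a limit)

For the measured compounds named here, compound 2 holds the only true number in this small set, at 650 nM. The remaining entries sit at the limit of > 50000 nM in this assay, at which 2 of the 3 values shown sit, so there is no second number to rank it against.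

Compound 4 `COC(=O)/C=C/c1oc(=O)c(CO)c(OC)c1CO` has not yet been measured. It is compound 2 with one change: hydrogen in place of acetyl on an oxygen on a saturated carbon, which turns acetoxymethyl into hydroxymethyl (hydrogen in place of acetyl on an oxygen on a saturated carbon). Going by the values given here, no measured pair isolates this change, so its effect cannot be read directly.

The available hints are indirect. Compound 3 carries hydroxymethyl, and its > 50000 nM is a limit. Compound 1 carries hydroxymethyl as well, and its > 50000 nM is also a limit. Both compounds differ from compound 2 in other ways too, which makes them a weak guide.

A moderate weakening is therefore expected, meaning a higher number in this assay, probably somewhat beyond the usual scatter. The expected step is a 2.8-fold higher number from compound 2 to compound 4 (0.44 log units; beyond the scatter). For compound 4 the estimated value is 1800 nM, with an expected range from 350 nM to 15000 nM.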

Compound 4, half-maximal inhibitory concentration: > 50000 nM
Compound 4: no number, only a limit (the forecaster's own chance of this, stated with the estimate: 12%); at least 27-fold (1.44 log units) between middle value and limit.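

For the compounds shown here, the pair of compound 2 and compound 4 now isolates this change, which the earlier compounds could not do. In this assay, putting hydrogen in place of acetyl on an oxygen on a saturated carbon, which turns acetoxymethyl into hydroxymethyl, gives an at least 76-fold higher number from compound 2 to compound 4 (1.88 log units; beyond the scatter), and the true gap may be wider still. Compound 4 gives > 50000 nM, which is a limit. Among the compounds shown, only compound 2 carries acetoxymethyl, and only compound 2 gives a true number rather than a limit: the limit of > 50000 nM in this assay, at which 3 of the 4 values shown sit.

As far as these compounds go, what stays open is whether acetyl itself matters or whether another group on this oxygen would serve as well, such as a longer acyl chain like butyryl, a benzoyl group or a simple methyl ether. Also open is how much the methyl ester of compound 2 contributes, as the compounds shown hold no pair that changes that group alone while acetoxymethyl stays in place.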